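The compounds below may be only part of what the source reports. "The series", "measured", "known", "first", "only" and "open" are said of these compounds alone.

Measured so far in a functional assay on A2780 cells (Homo sapiens) for inhibition; a lower number here means a stronger inhibitor, a higher number a weaker inhibitor:
- compound 1 `CCNC(=O)c1noc(-c2cc(C(C)C)c(O)cc2O)c1-c1cc(CN)no1`: "not determined" (no result reported)
- compound 2 `CCCNCc1cc(-c2c(C(=O)NCC)noc2-c2cc(C(C)C)c(O)cc2O)on1`: "not determined" (no result reported)
- compound 3 `CCNC(=O)c1cc(-c2c(C(=O)NCC)noc2-c2cc(C(C)C)c(O)cc2O)on1`: 43 nM

Only one of the three has a number: in this assay compound 3 gives 43 nM. Within the data shown here, for compound 1 and compound 2 no result was reported, so compound 3 cannot be ranked against anything, and no measured step shows how this series responds to a change.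

Compound 4 `CCNC(=O)c1noc(-c2cc(C(C)C)c(O)cc2O)c1-c1cnn(CC)c1` has not yet been measured. It keeps the shared core but carries 1-ethyl-1H-pyrazol-4-yl in place of 3-(ethylcarbamoyl)-1,2-oxazol-5-yl on an aromatic carbon. The exchange sits on a five-membered aromatic ring with 1 nitrogen and 1 oxygen, next to the ring atom that bears an ethylcarbamoyl group.

The data favour no direction for this exchange, so no step beyond the scatter is expected in this assay, though the uncertainty is wide. The only anchor for this expectation is compound 3 at 43 nM. The expected change is a 1.1-fold lower number from compound 3 to compound 4 (0.03 log units; within the scatter). For compound 4 the estimated value is 40 nM, with an expected range from 12 nM to 130 nM.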

Compound 4, half-maximal inhibitory concentration: 30 nM
Beside the measured number, compound 4's estimate is 1.3-fold (0.12 log units) above it; measured number inside the range.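

In this assay, among these compounds, replacing 3-(ethylcarbamoyl)-1,2-oxazol-5-yl with 1-ethyl-1H-pyrazol-4-yl gives a 1.4-fold lower number from compound 3 to compound 4 (0.16 log units; within the scatter), the first measured step, and the two compounds cannot be told apart. On this aromatic carbon, next to the ring atom that bears an ethylcarbamoyl group, the outer ring can thus change its hetero atoms, and the substituent can go from 10 heavy atoms to 7 and lose its only hydrogen-bond donor, with no change beyond the scatter, so in this single pair neither that donor nor the second ethylcarbamoyl group is needed to keep the value at this level. No independent measurement bears on why the two groups read alike.

Among the compounds shown here, with only one readable pair, it remains open whether other groups at this position would also leave the value in place, and the aminomethyl and propylaminomethyl groups of compound 1 and compound 2 cannot be read against it. A carboxylic acid on the outer ring, or a butyl chain in place of the ethyl on the pyrazole nitrogen, would be untested changes at this position, and the present pair does not indicate how either would read.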